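From cyclopentyl to 3-hydroxypropyl on compound 2

The source may report more compounds than this note shows. Statements on the series, on what has been measured and on what is new or still open speak of the compounds shown alone.

Measured in a functional assay on DU-145 cells (Homo sapiens) for antiproliferative activity, read by sulforhodamine B assay, with a stated time of 48 h (a lower number here means a stronger inhibitor of growth, a higher number a weaker inhibitor of growth), so far:
- compound 1 `COc1ccc(Nc2nc(NCCCO)c3ccccc3n2)cc1` gives 18300 nM
- compound 2 `N#Cc1ccc(Nc2nc(NC3CCCC3)c3ccccc3n2)cc1` gives > 31300 nM as a limit
- compound 3 `O=C(O)c1ccc(Nc2nc(NC3CCCC3)c3ccccc3n2)cc1` gives 27300 nM

Compound 2 sits at the limit of > 31300 nM in this assay, at which 1 of the 3 values shown sits, and therefore has no exact number. Going to compound 4 `N#Cc1ccc(Nc2nc(NCCCO)c3ccccc3n2)cc1` puts 3-hydroxypropyl in place of cyclopentyl on a nitrogen on an aromatic ring and leaves the rest of compound 2 unchanged.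

Among the compounds with values here, no measured step covers this exchange. Within the data shown here, the one step available is an at least 1.1-fold lower number from compound 2 to compound 3 (0.05 log units; that floor lies within the scatter) and it concerns the aromatic substituent, so it bears on the question only indirectly. Compound 1 also carries 3-hydroxypropyl and gives 18300 nM in this assay on a different aromatic substituent, so a measurable number is expected for compound 4. Compound 4 may, though, again reach the limit of the assay. A small move towards a lower number is therefore expected, and the estimated step is an at least 1.3-fold lower number from compound 2 to compound 4 (0.11 log units; that floor lies within the scatter) with wide uncertainty. For compound 4 the estimated value is 24000 nM with an expected range from 11000 nM to 50000 nM in this assay.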

Compound 4, concentration for 50% growth inhibition: 18700 nM
For compound 4 the middle estimate is 1.3-fold (0.11 log units) above the measured one; the measured number falls inside the stated range.
By their numbers in this assay, from the lowest: compounds 1, 4 and 3 (each within the scatter of the next). At a limit, above all of these: compound 2.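

Putting 3-hydroxypropyl in place of cyclopentyl on the nitrogen gives an exact number where there was none in this assay, and the change reads as an at least 1.6-fold lower number from compound 2 to compound 4 (0.22 log units; that floor lies within the scatter). This step is only a floor because compound 2 has no exact number: the limit of > 31300 nM in this assay, at which 1 of the 4 values shown sits.

With 3-hydroxypropyl held fixed, cyano in place of methoxy on an aromatic carbon gives a 1.0-fold higher number from compound 1 to compound 4 (0.01 log units; within the scatter), so these two aromatic substituents cannot be told apart in this assay.

The compounds shown leave open how a longer chain ending in hydroxy, or a chain ending in an amine, would read on this nitrogen. They also leave open whether a carboxylic acid on the aromatic carbon would read the same with 3-hydroxypropyl as with cyclopentyl.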